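The source may hold more compounds than are shown below. What is called first, only, known or untested is meant among the compounds shown, and "the series" means these compounds.

The compounds measured in a functional assay on A549 cells (Homo sapiens) for cytotoxicity, read by MTT assay, with a stated time of 72 h; on this read-out lower numbers stand for stronger inhibition and higher numbers for weaker inhibition:
compound 1 `CN(C)CCn1cnnc1-c1cc(Oc2ccc(NC(=O)N/N=C/c3c[nH]c4ccccc34)cc2F)ccn1`, 820 nM
compound 2 `CN(C)CCn1cnnc1-c1cc(Oc2ccc(NC(=O)N/N=C/c3cc(Br)c(O)c(Br)c3)cc2F)ccn1`, > 100000 nM, a limit of the assay
compound 3 `CN(C)CCn1cnnc1-c1cc(Oc2ccc(NC(=O)N/N=C/c3ccc(F)cc3Cl)cc2F)ccn1`, 1120 nM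

Compound 1 has the lowest of the two numbers; compound 3 lies nearest, a 1.4-fold higher number from compound 1 to compound 3 (0.14 log units; within the scatter), so the two cannot be ranked. Compound 4 `Cc1cc(/C=N/NC(=O)Nc2ccc(Oc3ccnc(-c4nncn4CCN(C)C)c3)c(F)c2)cc(C)c1O` differs from compound 1 by 4-hydroxy-3,5-dimethylphenyl in place of 1H-indol-3-yl on a carbon with a double bond to nitrogen. Going by the values given here, two measured steps bear on this. Putting a 2-chloro-4-fluorophenyl in place of the 1H-indol-3-yl gave a 1.4-fold higher number from compound 1 to compound 3 (0.14 log units; within the scatter), while a 3,5-dibromo-4-hydroxyphenyl gave an at least 120-fold higher number from compound 1 to compound 2 (2.08 log units; beyond the scatter), ending at the limit of > 100000 nM in this assay, at which 1 of the 3 values shown sits. The 4-hydroxy-3,5-dimethylphenyl of compound 4 resembles compound 2 more than compound 3, so a large rise in the number is expected, a 24-fold higher number from compound 1 to compound 4 (1.39 log units; beyond the scatter). Compound 4 is thus estimated at 20000 nM, within 2500 nM to 100000 nM, with a real chance that only a limit is reported.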

Compound 4, half-maximal inhibitory concentration: 1640 nM
For compound 4 the middle estimate is 12-fold (1.09 log units) above the measured one; measured number below the stated range.
By their numbers in this assay, from the lowest: compounds 1, 3 and 4 (each within the scatter of the next). At a limit, above all of these: compound 2.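

The 4-hydroxy-3,5-dimethylphenyl shows that a hydroxyl-bearing phenyl at this position need not abolish the effect in this assay: the result is a 2.0-fold higher number from compound 1 to compound 4 (0.30 log units; within the scatter) and a 1.5-fold higher number from compound 3 to compound 4 (0.17 log units; within the scatter). The hydroxyl is shared with the 3,5-dibromo-4-hydroxyphenyl, yet the result there is an at least 60-fold lower number from compound 2 to compound 4 (1.78 log units; beyond the scatter), so in these compounds the large gap goes with bromines versus methyls, not with the hydroxyl alone. The value of compound 2 is a limit: the limit of > 100000 nM in this assay, at which 1 of the 4 values shown sits.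

As far as these compounds go, what a 3,5-dibromophenyl without the hydroxyl would give remains open. So does the outcome with a 3,5-dimethyl-4-methoxyphenyl or an amine in place of the hydroxyl.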